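This account rests on a few compounds, and the source may have more. Where it says the series, first, only, none or still open, it means among the compounds named here.

Compound 1 `CCCS(=O)(=O)Nc1ccc(F)c(C(=O)c2n[nH]c3ncc(-c4ccccc4Cl)cc23)c1F` gives 9.3% in an assay for binding affinity to dual specificity mitogen-activated protein kinase kinase 4 (Homo sapiens), read by KINOMEscan, tested at 100 nM; a lower number here means a stronger effect, a higher number a weaker effect of the compound at the concentration tested.
Compound 2 `CCCS(=O)(=O)Nc1ccc(F)c(C(=O)c2n[nH]c3ncc(-c4cccc(C)c4)cc23)c1F` gives 15% in this assay.
Compound 3 `CCCS(=O)(=O)Nc1ccc(F)c(C(=O)c2n[nH]c3ncc(-c4cccc(N)c4)cc23)c1F` gives 1.6% in this assay.

Compound 3 stands nearest to compound 1, a number 7.7 percentage points lower from compound 1 to compound 3 (within the scatter), and furthest from compound 2, a number 13.4 percentage points lower from compound 2 to compound 3 (beyond the scatter). Compound 1 and compound 2 themselves differ by a number 5.7 percentage points higher from compound 1 to compound 2 (within the scatter).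

Compound 4 `CCCS(=O)(=O)Nc1ccc(F)c(C(=O)c2n[nH]c3ncc(-c4ccc(C(C)(C)C)cc4)cc23)c1F` has not been measured. It differs from compound 3 in this way: 4-(tert-butyl)phenyl in place of 3-aminophenyl on an aromatic carbon. Within the data shown here, the step that bears most directly on it is the one from compound 2 to compound 3, where the amino replaced a methyl and the number fell beyond the scatter; compound 4 carries neither amino nor any other donor or acceptor on that ring, so a move back toward the numbers of compound 1 and compound 2 is expected. For compound 4 the expected step in this assay is a number 18.4 percentage points higher from compound 3 to compound 4 (beyond the scatter), upward and modest. The estimate for compound 4 is 20%, with a range from 6% to 50%.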

Compound 4, a percentage reported as activity, at one concentration (the size of the read-out at that concentration, not a potency): 46%
Estimate against measurement, compound 4: 26 percentage points below, and the stated range covers the measured number.
By their numbers in this assay, from the lowest: compounds 3, 1 and 2 (each within the scatter of the next, the first and the last beyond it); then compound 4.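

In this assay, among these compounds, the three earlier compounds lay close together, with only the step from compound 2 to compound 3 beyond the scatter, whereas the 4-(tert-butyl)phenyl group sets a clearly higher number: a number 44.4 percentage points higher from compound 3 to compound 4 (beyond the scatter) and a number 31 percentage points higher from compound 2 to compound 4 (beyond the scatter) and a number 36.7 percentage points higher from compound 1 to compound 4 (beyond the scatter) are all large. Among the compounds shown here, this position therefore does not accept every phenyl substituent alike, and the spread at this carbon is much wider than the earlier compounds showed. Nothing measured here accounts for the rise.

The change alters both the substituent and its place on the phenyl ring, so these two cannot be told apart from the compounds shown. A 4-methylphenyl, a 4-aminophenyl or a 3-(tert-butyl)phenyl group at this carbon would bear on that question.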